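Swapping the anilino arm for a pyrrolidinyloxy group

This account rests on a few compounds, and the source may have more. Where it says the series, first, only, none or still open, it means among the compounds named here.

Compound 1 `Cc1ccc(Nc2ncc3c(n2)N(C)C(=O)N(c2cc(NC(=O)c4cccc(C(F)(F)F)c4)ccc2C)C3)cc1C` and compound 2 `Cc1ccc(Nc2ncc3c(n2)N(C)C(=O)N(c2cc(NC(=O)c4cccc(C(F)(F)F)c4)ccc2C)C3)cc1N` share one core and differ at a single aromatic carbon. In an ADME assay on BaF3 cells (Mus musculus) for antiproliferative activity, read by CellTiter-Glo and CCK-8 assay, with a stated time of 72 h (on this read-out lower numbers stand for stronger inhibition of growth and higher numbers for weaker inhibition of growth), compound 1 gives 3760 nM, while compound 2 gives 440 nM. Among the measured compounds shown here, the step of an 8.5-fold lower number from compound 1 to compound 2 (0.93 log units; beyond the scatter) is the only measured step here, and it places compound 2 at the lowest number of the two, with compound 1 as its only neighbour. Compound 3 `Cc1ccc(NC(=O)c2cccc(C(F)(F)F)c2)cc1N1Cc2cnc(O[C@H]3CCNC3)nc2N(C)C1=O` is built from compound 2 by a much larger exchange: (pyrrolidin-3-yl)oxy in place of (3-amino-4-methylphenyl)amino on an aromatic carbon. For the measured compounds named here, no measured step bears on this kind of change; the one step that exists, from compound 1 to compound 2, alters only a small substituent while the whole arm stays in place, and it gives no guide for replacing the arm altogether. With nothing to rest on, the expectation for compound 3 is a weaker result carried by a wide range. In this assay compound 3 is estimated at 3000 nM, with a range from 300 nM to 30000 nM. That estimate means an expected step of a 6.8-fold higher number from compound 2 to compound 3 (0.83 log units; beyond the scatter), uncertain in both size and direction.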

Compound 3, concentration for 50% growth inhibition: > 10000 nM
Compound 3: no number, only a limit; the forecaster's own chance of this, stated with the estimate: 15%; at least 3.3-fold (0.52 log units) between middle value and limit.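

Compound 3 gives no number, only a limit, in this assay: the limit of > 10000 nM in this assay, at which 1 of the 3 values shown sits.

Even so, the limit is enough to read both steps: the exchange gives an at least 22-fold higher number from compound 2 to compound 3 (1.35 log units; beyond the scatter), and against the other arm it gives an at least 2.6-fold higher number from compound 1 to compound 3 (0.42 log units; beyond the scatter). The earlier step, an 8.5-fold lower number from compound 1 to compound 2 (0.93 log units; beyond the scatter), showed only that a small substituent on the arm matters while the arm stays in place; these new steps show that the number also depends on the whole group on this aromatic carbon between two ring nitrogen atoms, and that (pyrrolidin-3-yl)oxy does not keep the growth inhibition seen with either aromatic arm.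

The exchange alters several things at once, including the ring, the linking atom and the defined stereocentre, so the compounds shown cannot say which of these accounts for the loss, and the limit hides its full size. Going by these compounds, a phenoxy group, which would keep an aromatic ring with an oxygen link, and a (pyrrolidin-3-yl)amino group, which would keep the saturated ring with a nitrogen link, are the kinds of group that could separate these changes, and how either would behave here remains open.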